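From tert-butoxy to cyclohexyl at the assay limit

The compounds below may be only part of what the source reports. "The series", "measured", "known", "first", "only" and "open" are said of these compounds alone.

Compound 1 (`COc1ccc(-c2scc3c(N4CC[C@@H](NC(C)=O)C4)nc(C)nc23)cc1OC`) gives > 95%
Compound 2 (`COc1ccc(-c2c(C)nc3c(N4CC[C@@H](NC(C)=O)C4)cc(C)nn23)cn1`) gives > 95%
Compound 3 (`COc1ccc(-c2c(C)nc3c(N4CCN(C(=O)OC(C)(C)C)CC4)cc(C)nn23)cc1OC`) gives > 95%

These values come from an ADME assay on microsomes from liver (Homo sapiens) for metabolic stability, read by LC-MS, with NADPH named in the record, with a stated time of 60 min, tested at 1 uM, in the absence of a further agent (on this read-out higher numbers stand for a more stable compound and lower numbers for a less stable compound), and all reach the same ceiling, (the limit of > 95% in this assay, at which 3 of the 3 values shown sit), so none is an exact number. Compound 3 stands at > 95% as a limit of the assay. Compound 4 (`COc1ccc(-c2c(C)nc3c(N4CCN(C(=O)C5CCCCC5)CC4)cc(C)nn23)cc1OC`) has cyclohexyl in place of tert-butoxy on a carbonyl carbon. For the measured compounds named here, no measured pair differs in one place, so the data offer no step size as a guide. A small fall in this assay is expected, close to the usual scatter. The estimated change is a number at least 5 percentage points lower from compound 3 to compound 4 (that floor lies within the scatter) as a rough guide only. For compound 4 the expected value is 90%, with an estimated range from 70% to 100%.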

Compound 4, percent of the compound remaining: > 95%
Compound 4: only a limit was reported; the forecaster's own chance of this, stated with the estimate: 40%; middle value at least 5 percentage points away from the limit.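

No step from compound 3 to compound 4 can be read, because both values are limits rather than exact numbers: the limit of > 95% in this assay, at which 4 of the 4 values shown sit.

As far as these compounds go, whether cyclohexyl in place of tert-butoxy changes metabolic stability at all remains open.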